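The compounds below may be only part of what the source reports. "The series", "measured", "known", "first", "only" and "open" are said of these compounds alone.

Measured compounds:

compound 1, `O=C(O)C1C(C(=O)NCCCc2ccccc2)[C@H]2CC[C@@H]1O2`: 10000 nM
compound 2, `Cc1cc(C)c(NC(=O)C2C(C(=O)O)[C@@H]3CC[C@H]2O3)c(C)c1`: 10000 nM
compound 3, `O=C(O)C1C(C(=O)Nc2ccc(CO)cc2)[C@H]2CC[C@@H]1O2`: 10000 nM

Three amides built on a shared bicyclic acid core have been tested in an ADME assay on SW480 cells (Homo sapiens) for cytotoxicity, read by MTT assay, with a stated time of 72 h; a higher number here means a weaker inhibitor of growth, a lower number a stronger inhibitor of growth. Compound 1 gives 10000 nM in this assay. Compound 2 gives 10000 nM, and compound 3 gives 10000 nM. Compound 1 thus stands level with both compound 2 and compound 3 at the digits shown, and none of the three is separated from the others by more than the scatter of the measurement, so no order can be read among them.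

The next compound in the series is compound 4, `CCCCCCCCNC(=O)C1C(C(=O)O)[C@@H]2CC[C@H]1O2`, which has not yet been measured in this assay. Relative to compound 1 the change is pentyl in place of phenyl on a saturated chain carbon, three bonds along the chain from an amide-type nitrogen. The core and the amide linkage are untouched; only the group at the end of the chain is exchanged.

Within the data shown here, no pair of measured compounds differs in a single place, so there is no measured step to lean on. Given that compound 1, compound 2 and compound 3 sit at one level, the exchange at the far end of the chain is expected to leave compound 4 at about the same level, with the estimated step from compound 1 to compound 4 being no change at the digits printed from compound 1 to compound 4 (within the scatter), no change beyond the scatter. Compound 4 is therefore estimated at 10000 nM in this assay, in the range 5000 nM to 25000 nM.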

Compound 4, concentration for 50% growth inhibition: 10000 nM
Compound 4: the middle estimate sits on the measured number at the digits printed; low and high end bracket the measured number.
By their numbers in this assay, from the lowest: compounds 1, 2, 3 and 4 (each within the scatter of the next).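

In this assay, among these compounds, the exchange of pentyl for phenyl on a saturated chain carbon, three bonds along the chain from an amide-type nitrogen, gives no change at the digits printed from compound 1 to compound 4 (within the scatter) and is the only measured step here that changes a single place. Among the compounds shown here, it shows that, at this position, the six-membered aromatic ring can give way to an open saturated chain with no change in the reading beyond the scatter, something the earlier compounds could not show, as none of them differed from another in one place alone. No measurement at hand accounts for this result.

The compounds shown leave open whether an amine, a hydroxyl group or a carboxylic acid at the far end of this chain would move the reading in this assay away from the level shared by all four compounds. For the compounds shown here, they also leave open whether a longer chain than the one in compound 4, or an ester in place of the carboxylic acid on the shared core, would stay at that level.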